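Swapping methoxy for chloro on the aryl of compound 2

The source may report more compounds than this note shows. Statements on the series, on what has been measured and on what is new or still open speak of the compounds shown alone.

In a functional assay on U-87MG ATCC cells for antiproliferative activity against U-87 MG (Homo sapiens), read by MTT assay, with a stated time of 48 h, tested at 50 uM (on this read-out lower numbers stand for a stronger effect and higher numbers for a weaker effect at the one concentration tested), compound 2 `COc1ccc(-c2nc(C)c(C(=O)CSc3nc(-c4cccc(OC)c4)c(C#N)c(=O)[nH]3)s2)cc1` gives 43.2%, the lowest of the three numbers. Compound 1 `COc1cccc(-c2nc(SCC(=O)c3sc(-c4ccc(Cl)cc4)nc3C)[nH]c(=O)c2C#N)c1` gives 47.6%, a value within the scatter of compound 2, while compound 3 `Cc1nc(-c2ccccc2)sc1C(=O)CSc1nc(-c2ccc(Cl)cc2)c(C#N)c(=O)[nH]1` gives 63.4%, beyond the scatter from compound 2. Compound 4 `COc1ccc(-c2nc(C)c(C(=O)CSc3nc(-c4cccc(Cl)c4)c(C#N)c(=O)[nH]3)s2)cc1` differs from compound 2 by chloro in place of methoxy on an aromatic carbon. Going by the values given here, the one measured step that bears on this exchange is a number 4.4 percentage points lower from compound 1 to compound 2 (within the scatter), the same pair of groups traded in the opposite direction. That step lay within the scatter, so for compound 4 he expects no change beyond the scatter in this assay, if anything a slightly higher number, as a number 3.8 percentage points higher from compound 2 to compound 4 (within the scatter). His estimate for compound 4 is therefore 47%, expected to fall between 35% and 60%.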

Compound 4, a percentage reported as activity, at one concentration (the size of the read-out at that concentration, not a potency): 83.4%
Compound 4: middle estimate off by 36.4 percentage points, on the low side; the whole stated range lies below it.
By their numbers in this assay, from the lowest: compounds 2 and 1 (each within the scatter of the next); then compound 3; then compound 4.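

In this assay the change from 3-methoxyphenyl to 3-chlorophenyl gives a number 40.2 percentage points higher from compound 2 to compound 4 (beyond the scatter), so at this position the exchange carries a large loss of effect at the one concentration tested. The same pair of groups traded on the other aryl ring gave a number 4.4 percentage points lower from compound 1 to compound 2 (within the scatter), so the outcome of this exchange depends on which ring carries it. Nothing measured here explains that difference. From the compounds shown here alone, whether a hydroxyl, an ethoxy or a plain hydrogen at this position would match the methoxy stays open.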